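A Methoxy Group Added to the Anilide of Compound 2

The compounds below may be only part of what the source reports. "The series", "measured", "known", "first", "only" and "open" are said of these compounds alone.

Compound 1, `CCN(CC)C(=O)CN(c1cc(Cl)ccc1OC)S(=O)(=O)c1ccccc1`: in a functional assay on SH-SY5Y cells (Homo sapiens), read by MTT assay, with a stated time of 24 h (a higher number here means that more compound is needed for the effect, a lower number that less compound is needed), compound 1 reaches only a limit, > 20000 nM.
Compound 2, `COc1ccc(Cl)cc1N(CC(=O)Nc1ccccc1)S(=O)(=O)c1ccccc1`: in this assay compound 2 likewise reaches only a limit, > 20000 nM.
Compound 3, `COc1ccc(Cl)cc1N(CC(=O)Nc1cccc2ccccc12)S(=O)(=O)c1ccccc1`: in this assay compound 3 gives 17400 nM.

Compound 2 therefore stands at the limit of this assay, the point at which (the limit of > 20000 nM in this assay, at which 2 of the 3 values shown sit). Compound 4, `COc1ccc(NC(=O)CN(c2cc(Cl)ccc2OC)S(=O)(=O)c2ccccc2)cc1`, differs from compound 2 by methoxy in place of hydrogen on an aromatic carbon. Among the compounds with values here, none of the measured steps touches this change. The step that the two limits leave unreadable from compound 1 to compound 2 cannot be read at all, and the steps of an at least 1.1-fold lower number from compound 1 to compound 3 (0.06 log units; that floor lies within the scatter) and an at least 1.1-fold lower number from compound 2 to compound 3 (0.06 log units; that floor lies within the scatter) both replace the whole partner on the carbonyl carbon or on the amide-type nitrogen, not a hydrogen on that partner, and both stay within the scatter. Within the data shown here, with no comparable step available, the expected change from compound 2 to compound 4 is a step that the limit leaves unreadable from compound 2 to compound 4, that is, none beyond the scatter. Compound 4 is thus expected to sit around 25000 nM, with a range of 10000 nM to 80000 nM, most likely again reported only as a limit.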

Compound 4, half-maximal effective concentration: 16200 nM
Beside the measured number, compound 4's estimate is 1.5-fold (0.19 log units) above it; measured number inside the range.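

In this assay, methoxy in place of hydrogen on an aromatic carbon of the anilino group gives an at least 1.2-fold lower number from compound 2 to compound 4 (0.09 log units; that floor lies within the scatter), so this change turns a reading without a number into a measured one, although the floor of the step stays within the scatter. Compound 2 itself stands only at a limit: the limit of > 20000 nM in this assay, at which 2 of the 4 values shown sit. Set against the other partners on the carbonyl carbon, the 4-methoxyphenyl partner gives a 1.1-fold lower number from compound 3 to compound 4 (0.03 log units; within the scatter), which leaves it indistinguishable from naphthalen-1-yl, while the (4-methoxyphenyl)amino group gives an at least 1.2-fold lower number from compound 1 to compound 4 (0.09 log units; that floor lies within the scatter).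

From the compounds shown here alone, how large the true step from compound 2 is remains open. Also open, going by these compounds, is whether a hydroxy group or an amine in the same place would read any differently from methoxy.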